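This account rests on a few compounds, and the source may have more. Where it says the series, first, only, none or still open, it means among the compounds named here.

The series shares one core and differs only in the aryl group on the carbon with a double bond to nitrogen. Compound 1 `O=C(CSc1nnc(-c2ccncc2)o1)N/N=C/c1ccc(Br)cc1` gives 24500 nM in a functional assay on BGC-823 cells (Homo sapiens) for cytotoxicity, read by MTT assay, with a stated time of 48 h; a lower number here means a stronger inhibitor, a higher number a weaker inhibitor. Compound 2 `Cc1ccc(/C=N/NC(=O)CSc2nnc(-c3ccncc3)o2)cc1` gives 21800 nM in that assay, and compound 3 `O=C(CSc1nnc(-c2ccncc2)o1)N/N=C/c1cc(Cl)cc(Cl)c1O` gives 6340 nM. Compound 2 thus stands second highest of the three numbers: the step of a 1.1-fold lower number from compound 1 to compound 2 (0.05 log units; within the scatter) is within the scatter, whereas the step of a 3.4-fold lower number from compound 2 to compound 3 (0.54 log units; beyond the scatter) is beyond the scatter.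

Compound 4 `COc1cc(/C=N/NC(=O)CSc2nnc(-c3ccncc3)o2)ccc1O` has not yet been measured in this assay. Its difference from compound 2 is 4-hydroxy-3-methoxyphenyl in place of 4-methylphenyl on a carbon with a double bond to nitrogen. Among the compounds with values here, the steps that bear on this are those in which a hydroxyl-bearing aryl replaces a simple substituted phenyl: a 3.4-fold lower number from compound 2 to compound 3 (0.54 log units; beyond the scatter) and a 3.9-fold lower number from compound 1 to compound 3 (0.59 log units; beyond the scatter), both modest gains. Within the data shown here, the entering group of compound 4 carries a hydroxyl, as does that of compound 3, but lacks the two chloro groups, and no measured step shows what a methoxy group alone does here. Compound 4 is therefore expected to show a modest step, a 1.8-fold lower number from compound 2 to compound 4 (0.26 log units; within the scatter), toward a lower number, with considerable uncertainty. The estimate for compound 4 in this assay is 12000 nM, with a range from 4000 nM to 30000 nM.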

Compound 4, half-maximal inhibitory concentration: 4320 nM
Compound 4: middle estimate off by 2.8-fold (0.44 log units), on the high side; the measured number falls inside the stated range.
By their numbers in this assay, from the lowest: compounds 4 and 3 (each within the scatter of the next); then compounds 2 and 1 (each within the scatter of the next).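

In this assay, the step of a 5.0-fold lower number from compound 2 to compound 4 (0.70 log units; beyond the scatter) and the step of a 5.7-fold lower number from compound 1 to compound 4 (0.75 log units; beyond the scatter) show that on the carbon with a double bond to nitrogen, a hydroxyl-bearing aryl with no chloro group can also give a number beyond the scatter of those of the 4-methylphenyl and 4-bromophenyl compounds, so among these compounds the two chloro groups of compound 3 are not required for such a gain. The step of a 1.5-fold lower number from compound 3 to compound 4 (0.17 log units; within the scatter) lies within the scatter, which means that 4-hydroxy-3-methoxyphenyl and 3,5-dichloro-2-hydroxyphenyl cannot be told apart at this position, although they carry different groups besides the hydroxyl. Nothing at hand explains why these two aryl groups give such similar numbers.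

Each hydroxyl shown comes with other groups, a methoxy in compound 4 and two chloro groups in compound 3, so what a hydroxyl alone or a methoxy alone does on the phenyl ring remains open. Also open, going by these compounds, is whether an amine or a carboxylic acid in place of that hydroxyl would keep the number as low.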